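Pyrazoline series: adding chloro to the weakest analogue

The source may hold more compounds than are shown below. What is called first, only, known or untested is meant among the compounds shown, and "the series" means these compounds.

Two members of the series have numbers in an assay on isolated protein for inhibition of Amine oxidase [flavin-containing] A (Bos taurus) (on this read-out lower numbers stand for stronger inhibition and higher numbers for weaker inhibition), so far. Compound 1 `CCC(=O)N1N=C(c2ccc(F)cc2)CC1c1ccc(Cl)cc1` gives 1410 nM, while compound 2 `CCC(=O)N1N=C(c2ccc(OC)cc2)CC1c1ccccc1` gives 63100 nM, the highest of the two numbers and beyond the scatter from compound 1; the two differ in two places at once, so their values are set side by side without a step read off them. Compound 3 `CCC(=O)N1N=C(c2ccc(OC)cc2)CC1c1ccc(Cl)cc1` is the next to be measured. It is compound 2 with chloro in place of hydrogen on an aromatic carbon, on an aromatic carbon of a six-membered aromatic ring of carbon only, para to a large group. For the measured compounds named here, no measured pair shows this change alone. Compound 1 carries a chloro at the same place and sits far lower than compound 2, so the step from compound 2 to compound 3 is expected to be downward and beyond the scatter, a 7.9-fold lower number from compound 2 to compound 3 (0.90 log units; beyond the scatter). Compound 3 is accordingly estimated at 8000 nM, with a range from 2000 nM to 30000 nM in this assay.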

Compound 3, half-maximal inhibitory concentration: 832 nM
Estimate against measurement, compound 3: 9.6-fold (0.98 log units) above; measured number outside the range, below it.
By their numbers in this assay, from the lowest: compounds 3 and 1 (each within the scatter of the next); then compound 2.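

In this assay, phenyl to 4-chlorophenyl now stands alone as a single change, with a 76-fold lower number from compound 2 to compound 3 (1.88 log units; beyond the scatter); this position therefore responds strongly to chloro in place of hydrogen, which the earlier pair, differing in two places at once, could not show. With chloro present, methoxy in place of fluoro on an aromatic carbon gives a 1.7-fold lower number from compound 1 to compound 3 (0.23 log units; within the scatter), so this pair shows no readable difference between those two groups. Nothing measured here bears on why the chloro step is so large.

On these data alone, it remains open whether the step is particular to chloro or would also appear with bromo, methyl or a nitrile at the same place. As far as these compounds go, it is also open whether chloro in place of hydrogen would give a step of similar size with fluoro instead of methoxy.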